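The compounds below may be only part of what the source reports. "The series", "measured", "known", "first", "only" and "open" are said of these compounds alone.

Measured so far in a functional assay on MCF7 cells (Homo sapiens) for cytotoxicity, read by MTT assay, with a stated time of 96 h; a higher number here means a weaker inhibitor, a lower number a stronger inhibitor:
- compound 1, `COc1cc(C(=O)c2cn(-c3ccccc3)cc2-c2cccc([N+](=O)[O-])c2)cc(OC)c1OC`: 50 nM
- compound 2, `COc1cc(C(=O)c2cn(-c3ccccc3)cc2-c2ccc([N+](=O)[O-])cc2)cc(OC)c1OC`: 590 nM
- compound 3, `COc1cc(C(=O)c2cn(-c3ccc(N)cc3)cc2-c2cccc([N+](=O)[O-])c2)cc(OC)c1OC`: 260 nM

Compound 1 carries the lowest number of the three in this assay. Compound 2 differs from it only by 4-nitrophenyl in place of 3-nitrophenyl on an aromatic carbon, and that change gives a 12-fold higher number from compound 1 to compound 2 (1.07 log units; beyond the scatter). Compound 3 differs from compound 1 by amino in place of hydrogen on an aromatic carbon, which gives a 5.2-fold higher number from compound 1 to compound 3 (0.72 log units; beyond the scatter). Compound 2 and compound 3 are not joined by a single counted step; their values simply show compound 3 with the lower number of the two, by a margin the scatter does not cover.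

Compound 4, `COc1cc(C(=O)c2cn(-c3ccc(N)cc3)cc2-c2ccc([N+](=O)[O-])cc2)cc(OC)c1OC`, has not yet been run in this assay. It differs from compound 3 by 4-nitrophenyl in place of 3-nitrophenyl on an aromatic carbon. This is the same kind of change as that from compound 1 to compound 2, not the same change: in the earlier pair the ring atom two bonds away bears a phenyl group (6 heavy atoms), whereas here it bears a 4-aminophenyl group (7 heavy atoms). Among the measured compounds shown here, only one measured instance of the change exists, so the expectation rests on that single pair. Compound 4 is expected to give about 2500 nM in this assay, with a range of 800 nM to 8000 nM, because the earlier step was a 12-fold higher number from compound 1 to compound 2 (1.07 log units; beyond the scatter). The expected step is a 9.6-fold higher number from compound 3 to compound 4 (0.98 log units; beyond the scatter), taken slightly below the earlier one to allow for the different surroundings.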

Compound 4, half-maximal inhibitory concentration: 260 nM
Compound 4: middle estimate off by 9.6-fold (0.98 log units), on the high side, and the stated range ends above it.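

In this assay, 4-nitrophenyl in place of 3-nitrophenyl does not carry over from the core of compound 1 to the core bearing a 4-aminophenyl group: the change now gives no change at the digits printed from compound 3 to compound 4 (within the scatter), and the two instances of the change differ: the same change on two cores in this assay, a 12-fold higher number (1.07 log units; beyond the scatter) from compound 1 to compound 2 and no change at the digits printed (within the scatter) from compound 3 to compound 4, 12-fold (1.07 log units) apart, beyond the scatter of two such steps. The amino change also fails to carry over, giving a 2.3-fold lower number from compound 2 to compound 4 (0.36 log units; beyond the scatter) on the 4-nitrophenyl series, opposite in direction to its effect on the 3-nitrophenyl series: the same change on two cores in this assay, a 5.2-fold higher number (0.72 log units; beyond the scatter) from compound 1 to compound 3 and a 2.3-fold lower number (0.36 log units; beyond the scatter) from compound 2 to compound 4, 12-fold (1.07 log units) apart, beyond the scatter of two such steps. The two changes therefore do not act independently across these four compounds, so a step measured on one core is a poor guide to the same step on the other, but this rests on a single set of four compounds and shows neither the reason for the dependence nor whether it extends to other groups.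

Still open, on these data alone, is whether the dependence is specific to the amino group or would also appear with a hydroxyl, a methoxy or a fluorine in its place. Also open, as far as these compounds go, is whether a nitrile or an amine in place of the nitro group would show the same dependence on the core.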